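One Chloro Group Less: What to Expect for Compound 4

The source may hold more compounds than are shown below. What is called first, only, known or untested is meant among the compounds shown, and "the series" means these compounds.

Compound 1, `CCCCSC(=S)C1=C(Nc2ccc(Cl)cc2Cl)CC(C)(C)CC1=O`, in a functional assay on cells (blood, Homo sapiens) for inhibition, read by chemiluminescence, with a stated time of 30 min (a higher number here means a weaker inhibitor, a lower number a stronger inhibitor), gives > 100 ug/mL, a limit of the assay.
Compound 2, `CC1(C)CC(=O)C(C(=S)SCc2ccccc2)=C(Nc2ccc(Cl)cc2Cl)C1`, in this assay gives > 100 ug/mL, also a limit.
Compound 3, `CC1(C)CC(=O)C(C(=S)SCCO)=C(Nc2ccc(Cl)cc2Cl)C1`, in this assay gives > 100 ug/mL, again a limit.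

All three values sit at the limit of > 100 ug/mL in this assay, at which 3 of the 3 values shown sit, so compound 1 stands at the limit and has no number of its own. Compound 4, `CCCCSC(=S)C1=C(Nc2ccc(Cl)cc2)CC(C)(C)CC1=O`, differs from compound 1 by hydrogen in place of chloro on an aromatic carbon. The measured steps a step that the two limits leave unreadable from compound 1 to compound 2, a step that the two limits leave unreadable from compound 1 to compound 3 and a step that the two limits leave unreadable from compound 2 to compound 3 all run between limits and give no readable size, and none of them changes the 2,4-dichlorophenyl group. Nothing measured therefore points to a readable step in this assay for compound 4, and a further limit is expected. Compound 4 is expected to give 150 ug/mL, between 60 ug/mL and 400 ug/mL. The step that the limit leaves unreadable from compound 1 to compound 4 is accordingly expected to be none beyond the scatter.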

Compound 4, half-maximal inhibitory concentration: > 100 ug/mL
Compound 4: a limit, no number; the forecaster's own chance of this, stated with the estimate: 80%; the middle value is on the limit's open side.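

Among the compounds shown here, compound 1 and compound 4 both stand at a limit without a number, so no new step between them can be read in this assay: the limit of > 100 ug/mL in this assay, at which 4 of the 4 values shown sit. The compounds shown leave open whether 4-chlorophenyl in place of 2,4-dichlorophenyl changes inhibition at all.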